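Nitro in place of methoxy: working notes

The source may report more compounds than this note shows. Statements on the series, on what has been measured and on what is new or still open speak of the compounds shown alone.

In an ADME assay on HT-29 cells (Homo sapiens) for inhibition, read by trypan blue exclusion, with a stated time of 72 h (a lower number here means a stronger inhibitor of growth, a higher number a weaker inhibitor of growth), compound 1 (`O=C(/C=C/c1ccccc1)c1ccccc1C(F)(F)F`) gives 10800 nM and compound 2 (`COc1ccccc1C(=O)/C=C/c1ccccc1`) gives 14800 nM (two numbers within the scatter of each other). For the measured compounds named here, compound 2 therefore holds no clear rank on the numbers so far. The change to compound 3 (`O=C(/C=C/c1ccccc1)c1ccccc1[N+](=O)[O-]`) is nitro in place of methoxy on an aromatic carbon, ortho to a large group (nitro in place of methoxy on an aromatic carbon). Going by the values given here, one measured step bears on it, an exchange of trifluoromethyl for methoxy on that same aromatic carbon: a 1.4-fold higher number from compound 1 to compound 2 (0.14 log units; within the scatter) and thus within the scatter. Among the compounds with values here, with only that step as a guide, no step beyond the scatter is expected in this assay for nitro. The estimated step is a 1.2-fold lower number from compound 2 to compound 3 (0.09 log units; within the scatter) and stays within the scatter. For compound 3 the estimate is 12000 nM with an expected range of 5000 nM to 28000 nM in this assay.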

Compound 3, concentration for 50% growth inhibition: 8300 nM
Beside the measured number, compound 3's estimate is 1.4-fold (0.16 log units) above it; measured number inside the range.
By their numbers in this assay, from the lowest: compounds 3, 1 and 2 (each within the scatter of the next).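

In this assay, nitro on this aromatic carbon, ortho to a large group, gives a 1.8-fold lower number from compound 2 to compound 3 (0.25 log units; within the scatter), and in place of trifluoromethyl it gives a 1.3-fold lower number from compound 1 to compound 3 (0.11 log units; within the scatter). All three groups at this position now lie within the scatter of one another, so neither nitro step separates it from methoxy or trifluoromethyl, even though methoxy and nitro differ in their counts of heavy atoms and hydrogen-bond acceptors. No measurement at hand bears on what lies behind these numbers.

As far as these compounds go, whether an amine or a carboxylic acid on this carbon would give a step beyond the scatter remains open. The compounds shown also leave open whether nitro would give a similar result elsewhere on the shared core.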